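The source may hold more compounds than are shown below. What is called first, only, known or untested is meant among the compounds shown, and "the series" means these compounds.

Two compounds share one core and differ only in the group that sits on a saturated chain carbon bound to an aromatic nitrogen. Compound 1 `COc1ccc([C@@H]2CC(=O)c3c(O)cc(OCc4cn(Cc5ccccc5Cl)nn4)cc3O2)cc1O` carries a 2-chlorophenyl there, and in a functional assay on RAW264.7 cells (Mus musculus) for inhibition, read by Griess assay, with stated times of 2 h and 24 h (a lower number here means a stronger inhibitor, a higher number a weaker inhibitor), compound 1 gives 6140 nM. Going by the values given here, compound 2 `COc1ccc([C@@H]2CC(=O)c3c(O)cc(OCc4cn(Cc5ccc(F)cc5)nn4)cc3O2)cc1O` carries a 4-fluorophenyl instead, and in this assay compound 2 gives 15100 nM, the higher of the two numbers; the only measured step, a 2.5-fold higher number from compound 1 to compound 2 (0.39 log units; beyond the scatter), separates them. Compound 3 `COc1ccc([C@@H]2CC(=O)c3c(O)cc(OCc4cn(Cc5ccccc5C)nn4)cc3O2)cc1O` is not yet measured; it differs from compound 2 by 2-methylphenyl in place of 4-fluorophenyl on a saturated chain carbon bound to an aromatic nitrogen. Among the compounds with values here, the one step that bears on this change is a 2.5-fold higher number from compound 1 to compound 2 (0.39 log units; beyond the scatter), which moved away from a 2-chlorophenyl and raised the number; the new group, 2-methylphenyl, is again a phenyl with a single group at the 2-position, so some return toward the number of compound 1 is expected. The step of a 1.9-fold lower number from compound 2 to compound 3 (0.28 log units; within the scatter) is therefore expected to be modest and downward. For compound 3 the expected value is 8000 nM, with a likely range from 3000 nM to 20000 nM.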

Compound 3, half-maximal inhibitory concentration: 13100 nM
Compound 3: the middle estimate sits 1.6-fold (0.21 log units) below what was measured; measured number inside the range.
By their numbers in this assay, from the lowest: compound 1; then compounds 3 and 2 (each within the scatter of the next).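

In this assay, 2-methylphenyl and 4-fluorophenyl on this saturated chain carbon cannot be told apart, with a 1.2-fold lower number from compound 2 to compound 3 (0.06 log units; within the scatter). Methyl in place of chloro on an aromatic carbon, however, gives a 2.1-fold higher number from compound 1 to compound 3 (0.33 log units; beyond the scatter), so among these three compounds only the 2-chlorophenyl of compound 1 goes with a clearly lower number. No measurement shown here accounts for these differences.

The compounds shown leave open whether this lower number belongs to chloro more widely, as 2-bromophenyl, 2-methoxyphenyl and 4-chlorophenyl on the same carbon could show. From the compounds shown here alone, it also remains open where an unsubstituted phenyl, or a phenyl carrying an amine, would fall relative to these three.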